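The source may report more compounds than this note shows. Statements on the series, on what has been measured and on what is new or still open speak of the compounds shown alone.

Measured compounds:
- compound 1 `NC1=C(C(=O)c2ccccc2)C(c2ccc(Br)cc2)N(CCCn2ccnc2)C1=O`: 169000 nM
- compound 2 `O=C(C1=C(Nc2ccccc2)C(=O)N(CCCn2ccnc2)C1c1ccc(Br)cc1)c1ccccc1`: 21200 nM
- compound 3 `Cc1ccc(NC2=C(C(=O)c3ccccc3)C(c3ccc(Br)cc3)N(CCCn3ccnc3)C2=O)cc1`: 25800 nM

In a functional assay on NCI-H1299 cells (Homo sapiens) for antiproliferative activity, read by MTT assay, with a stated time of 72 h (on this read-out higher numbers stand for weaker inhibition and lower numbers for stronger inhibition), compound 1 gives 169000 nM, the highest of the three numbers, so it is the weakest of the three measured compounds. Compound 4 `O=C(C1=C(Nc2ccc(OC(F)(F)F)cc2)C(=O)N(CCCn2ccnc2)C1c1ccc(Br)cc1)c1ccccc1` is not yet measured; it differs from compound 1 by 4-(trifluoromethoxy)phenyl in place of hydrogen on an amine nitrogen. Within the data shown here, two measured steps bear on this: an 8.0-fold lower number from compound 1 to compound 2 (0.90 log units; beyond the scatter) and a 6.6-fold lower number from compound 1 to compound 3 (0.82 log units; beyond the scatter), both modest gains beyond the scatter when an aryl group replaces the hydrogen on that amine nitrogen. The difference between the plain and the methyl-bearing aryl, a 1.2-fold higher number from compound 2 to compound 3 (0.09 log units; within the scatter), lies within the scatter. A similar gain is therefore expected for compound 4, a step of a 7.7-fold lower number from compound 1 to compound 4 (0.89 log units; beyond the scatter) in this assay. Compound 4 is estimated at 22000 nM, within a range from 8000 nM to 55000 nM.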

Compound 4, half-maximal inhibitory concentration: 11500 nM
For compound 4 the middle estimate is 1.9-fold (0.28 log units) above the measured one; the range from low to high includes it.
By their numbers in this assay, from the lowest: compounds 4, 2 and 3 (each within the scatter of the next, the first and the last beyond it); then compound 1.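

In this assay, among these compounds, the step to 4-(trifluoromethoxy)phenyl on the amine nitrogen reads a 15-fold lower number from compound 1 to compound 4 (1.17 log units; beyond the scatter) and is the first large step at this position. Trifluoromethoxy in place of methyl gives a 2.2-fold lower number from compound 3 to compound 4 (0.35 log units; beyond the scatter) and so separates two aryl groups for the first time, while trifluoromethoxy in place of hydrogen gives a 1.8-fold lower number from compound 2 to compound 4 (0.27 log units; within the scatter) and stays within the scatter. A group on the aryl ring can therefore matter here, but so far only against the methyl of compound 3.

On these data alone, how a chloro or methoxy group on that ring, or a benzyl group or plain alkyl chain on the nitrogen, would compare stays open. Nothing measured here explains the differences among these aryl groups.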